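Methyl to ethyl on the shared core

The compounds below may be only part of what the source reports. "The series", "measured", "known", "first", "only" and "open" are said of these compounds alone.

Values in a functional assay on DLD-1 cells (Homo sapiens) for cytotoxicity, read by MTT assay, with a stated time of 72 h (a lower number here means a stronger inhibitor, a higher number a weaker inhibitor), so far
- compound 1 `CN1C/C(=C\c2ccccc2F)C(=O)/C(=C/c2ccccc2F)C1` gives 810 nM
- compound 2 `CN1C/C(=C\c2cc(F)c(F)cc2F)C(=O)/C(=C/c2cc(F)c(F)cc2F)C1` gives 1800 nM
- compound 3 `CN1C/C(=C\c2c(F)cc(F)cc2F)C(=O)/C(=C/c2c(F)cc(F)cc2F)C1` gives > 10000 nM as a limit of the assay, not a number

Compound 1 holds the lowest of the two true numbers, and compound 2 stands higher, with that gap beyond the scatter. Among the compounds with values here, compound 4 `CCN1C/C(=C\c2ccccc2F)C(=O)/C(=C/c2ccccc2F)C1` has no measurement yet. It differs from compound 1 by methyl in place of hydrogen on a saturated chain carbon bound to an amine nitrogen in a ring, which also reads as methyl to ethyl. Within the data shown here, no measured pair carries this change. In this assay no step beyond the scatter is expected in either direction, though the uncertainty stays wide. That expectation rests on compound 1 at 810 nM as the only anchor. The estimated step is a 1.1-fold higher number from compound 1 to compound 4 (0.05 log units; within the scatter) and no more than that is expected. For compound 4 the estimated value is 900 nM with an expected range from 350 nM to 2500 nM in the coming measurement.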

Compound 4, half-maximal inhibitory concentration: 930 nM
Beside the measured number, compound 4's estimate is 1.0-fold (0.01 log units) below it, within the range that was stated.
By their numbers in this assay, from the lowest: compounds 1, 4 and 2 (each within the scatter of the next, the first and the last beyond it). At a limit, above all of these: compound 3.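

Compounds 1, 2 and 3 all share the methyl and differ only in their fluorine substitution, so they gave no reading at this place. In this assay, within the data shown here, methyl in place of hydrogen on a saturated chain carbon bound to an amine nitrogen in a ring gives a 1.1-fold higher number from compound 1 to compound 4 (0.06 log units; within the scatter) as the first reading here, so methyl to ethyl is tolerated in this single pair. No data at hand bear on why the value holds across this change.

As far as these compounds go, whether a longer chain such as propyl, or a chain ending in an amine or a carboxylic acid, is tolerated at this place stays open. Also open, from the compounds shown here alone, is whether methyl to ethyl reads the same with the fluorine substitution of compound 2.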